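A few compounds are considered here, and "the series" means these few. Any claim that something is new, unique, unknown or untested is made for them only; others in the source may bear on it.

Measured in an assay on isolated protein for inhibition of Gonadotropin-releasing hormone receptor (Rattus norvegicus); a higher number here means a weaker inhibitor, a lower number a stronger inhibitor: compound 1 `COc1ccc([N+](=O)[O-])cc1CSc1nc2cc(NC(=O)NC(C)(C)C)ccc2n1C1CC1` gives 860 nM; compound 2 `CCCCCn1c(SCc2cc([N+](=O)[O-])ccc2OC)nc2cc(NC(=O)NC(C)(C)C)ccc21` gives 880 nM; compound 3 `COc1ccc([N+](=O)[O-])cc1CSc1nc2cc(NC(=O)NC(C)(C)C)ccc2n1Cc1ccccc1` gives 160 nM.

Compound 3 stands lowest of the three, since a 5.4-fold lower number from compound 1 to compound 3 (0.73 log units; beyond the scatter) and a 5.5-fold lower number from compound 2 to compound 3 (0.74 log units; beyond the scatter) both lie beyond the scatter, whereas a 1.0-fold higher number from compound 1 to compound 2 (0.01 log units; within the scatter) does not. Compound 4 `COc1ccc([N+](=O)[O-])cc1CSc1nc2cc(NC(=O)NC(C)(C)C)ccc2n1Cc1ccccn1` differs from compound 3 by pyridin-2-yl in place of phenyl on a saturated chain carbon bound to an aromatic nitrogen. Among the measured compounds shown here, no measured step touches this ring: the steps recorded change the group on the aromatic nitrogen, and the benzyl group that gave the lowest number is kept here apart from the single ring nitrogen. For the measured compounds named here, with no step bearing directly on the change, a shift within the scatter is expected, a 1.3-fold higher number from compound 3 to compound 4 (0.10 log units; within the scatter). Compound 4 is therefore estimated at 200 nM in this assay, with a range of 70 nM to 600 nM.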

Compound 4, half-maximal inhibitory concentration: 670 nM
Compound 4: middle estimate off by 3.4-fold (0.53 log units), on the low side, and the stated range ends below it.
By their numbers in this assay, from the lowest: compound 3; then compounds 4, 1 and 2 (each within the scatter of the next).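

In this assay, the group on the aromatic nitrogen responds to a single ring atom: pyridin-2-yl in place of phenyl gives (a 4.2-fold higher number from compound 3 to compound 4 (0.62 log units; beyond the scatter)), so the advantage seen with benzyl does not carry over to (pyridin-2-yl)methyl. Compound 4 instead sits within the scatter of the cyclopropyl compound (a 1.3-fold lower number from compound 1 to compound 4 (0.11 log units; within the scatter)) and the pentyl compound (a 1.3-fold lower number from compound 2 to compound 4 (0.12 log units; within the scatter)). No evidence is available that explains this difference. The compounds shown leave open how pyridin-3-yl or pyridin-4-yl would compare at this place, and whether a fluorine or methoxy substituent on the benzyl ring would keep compound 3's number.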